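This account rests on a few compounds, and the source may have more. Where it says the series, first, only, none or still open, it means among the compounds named here.

Compound 1 `Cc1cc(O)cc(-c2nn(CC#N)cc2-c2ccnc(-c3ccc(Oc4ccccc4)cc3)c2)c1`: in a functional assay on U-251 cells (Homo sapiens) for cytotoxicity, read by sulforhodamine B assay, with a stated time of 48 h, tested at 0.01 uM (a higher number here means a weaker effect of the compound at the concentration tested, a lower number a stronger effect), compound 1 gives 92%.
Compound 2 `COc1cc(C)cc(-c2nn(CC#N)cc2-c2ccnc(-c3ccc(N(C)C)cc3)c2)c1`: in this assay compound 2 gives 105%.

Compound 2 stands highest of the two numbers; compound 1 lies lower by a margin beyond the usual scatter. Compound 3 `Cc1cc(O)cc(-c2nn(CC#N)cc2-c2ccnc(-c3ccc(N(C)C)cc3)c2)c1` is compound 2 with one change, (hydrogen in place of methyl on an oxygen on an aromatic ring). Among the measured compounds shown here, no measured pair shows this change, so its weight is unknown. Both measured values indicate little effect at the concentration tested, and the shift is expected to stay within the scatter, a number 6 percentage points lower from compound 2 to compound 3 (within the scatter). Compound 3 is therefore expected to give about 99%, with a range from 86% to 112%.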

Compound 3, a percentage reported as activity, at one concentration (the size of the read-out at that concentration, not a potency): 94%
Beside the measured number, compound 3's estimate is 5 percentage points above it; low and high end bracket the measured number.
By their numbers in this assay, from the lowest: compounds 1 and 3 (each within the scatter of the next); then compound 2.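

In this assay, hydrogen in place of methyl on the oxygen, methoxy to hydroxy, gives a number 11 percentage points lower from compound 2 to compound 3 (beyond the scatter), so this position responds to the change, though only modestly. With the hydroxy group in place, dimethylamino in place of phenoxy gives a number 2 percentage points higher from compound 1 to compound 3 (within the scatter), so this pair shows no readable difference. Nothing available explains either step. The compounds shown leave open whether an ethoxy group or an amine in place of the hydroxy would shift the number further. They also leave open how a carboxylic acid would read in place of dimethylamino.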